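Adding an amino group to the phenyl ring

A few compounds are considered here, and "the series" means these few. Any claim that something is new, unique, unknown or untested is made for them only; others in the source may bear on it.

Measured so far in a functional assay on HCT-116 cells (Homo sapiens) for cytotoxicity, read by MTT assay, with a stated time of 48 h; on this read-out higher numbers stand for weaker inhibition of growth and lower numbers for stronger inhibition of growth:
Compound 1 `CCn1c(C(F)(F)F)nc2cc(Cl)c(Cl)cc21` gives 95300 nM
Compound 2 `FC(F)(F)c1nc2cc(Cl)c(Cl)cc2n1Cc1ccccc1` gives 8600 nM

Of these two, compound 2 stands lowest at 8600 nM and so shows the stronger inhibition of growth. Compound 3 `Nc1cccc(Cn2c(C(F)(F)F)nc3cc(Cl)c(Cl)cc32)c1` differs from it by one change amino in place of hydrogen on an aromatic carbon in which amino replaces hydrogen on an aromatic carbon, turning phenyl to 3-aminophenyl. Among the compounds with values here, the only measured step of an 11-fold lower number from compound 1 to compound 2 (1.04 log units; beyond the scatter) is large and shows that this part of the molecule can move the number. That step bears only loosely on the new change, however, since it put phenyl in place of methyl and involved no amino group. Within the data shown here, no measured pair shows what amino does here, so neither size nor direction is firmly supported. The expected result in this assay is a 1.4-fold lower number from compound 2 to compound 3 (0.16 log units; within the scatter) and thus no step beyond the scatter. For compound 3 the estimated value is 6000 nM with 2000 nM to 18000 nM as the expected range.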

Compound 3, concentration for 50% growth inhibition: 22600 nM
The estimate for compound 3 lay 3.8-fold (0.58 log units) below the measured number; the measured number lies above the stated range.
By their numbers in this assay, from the lowest: compound 2; then compound 3; then compound 1.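

In this assay the phenyl ring of compound 2 proves sensitive to a single added group: amino in place of hydrogen gives a 2.6-fold higher number from compound 2 to compound 3 (0.42 log units; beyond the scatter) and so weakens the inhibition of growth. The ring still counts for more than this change does, since 3-aminophenyl in place of methyl gives a 4.2-fold lower number from compound 1 to compound 3 (0.62 log units; beyond the scatter) and compound 3 thus keeps part of the gain that phenyl brought over methyl. Nothing measured here explains why amino weakens the inhibition.

One substituted compound cannot show whether the loss belongs to this place on the ring or would follow amino elsewhere on it. It also leaves open whether a hydroxyl, a methoxy or a chlorine on the same aromatic carbon would move the number in the same direction.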